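A Methyl Added to the Carboxymethyl Amide Chain

The source may hold more compounds than are shown below. What is called first, only, known or untested is meant among the compounds shown, and "the series" means these compounds.

Measured in a functional assay on HeLa cells (Homo sapiens) for antiproliferative activity, read by MTT assay, with a stated time of 48 h; on this read-out lower numbers stand for stronger inhibition and higher numbers for weaker inhibition:
Compound 1 `COC(=O)[C@H](C)NC(=O)c1ccc(Oc2nc3ccccc3nc2NC(C)(C)C)cc1`: 55200 nM
Compound 2 `CC(C)(C)Nc1nc2ccccc2nc1Oc1ccc(C(=O)NCC(=O)O)cc1`: > 50000 nM

In this assay compound 2 gives > 50000 nM, which is a limit of the assay and not a number. Compound 3 `C[C@H](NC(=O)c1ccc(Oc2nc3ccccc3nc2NC(C)(C)C)cc1)C(=O)O` differs from it by one change, (methyl in place of hydrogen on a saturated chain carbon bound to an amide-type nitrogen and a carbonyl carbon), which reads as carboxymethyl to 1-carboxyethyl.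

Going by the values given here, only one measured step bears on this change: a step that the limit leaves unreadable from compound 1 to compound 2. It alters the same substituent on the amide nitrogen, but its size cannot be read, so it offers no size to carry over. No direction is therefore expected, and no step beyond the scatter. Among the compounds with values here, the only true number in the pair is that of compound 1 at 55200 nM, and compound 3 is expected to stay in that region. Compound 3 may quite possibly be reported only as a limit. The expected change is a step that the limit leaves unreadable from compound 2 to compound 3. For compound 3 the estimated value is 60000 nM. The expected range for compound 3 runs from 30000 nM to 120000 nM.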

Compound 3, half-maximal inhibitory concentration: 23400 nM
For compound 3 the middle estimate is 2.6-fold (0.41 log units) above the measured one, outside the stated range (below it).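

In this assay, methyl in place of hydrogen on the saturated chain carbon bound to an amide-type nitrogen and a carbonyl carbon gives an at least 2.1-fold lower number from compound 2 to compound 3 (0.32 log units; beyond the scatter), so this position responds to the change. Going by these compounds alone, the value of compound 2 is a limit of the assay and not a number, so the step from compound 1 to compound 2 cannot be read and the step to the methyl compound has only a bound on its size: the limit of > 50000 nM in this assay, at which 1 of the 3 values shown sits. With the methyl on that chain carbon kept in place, the carboxylic acid in place of the methyl ester gives a 2.4-fold lower number from compound 1 to compound 3 (0.37 log units; beyond the scatter), the first readable comparison of ester and acid on this chain.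

The compounds shown leave open whether a longer chain, such as ethyl, on the same carbon would carry the step further, and whether the opposite configuration at that carbon would match compound 3. They also leave open whether an amine or a primary amide in place of the carboxylic acid would keep the number of compound 3 or lose it.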